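The compounds below may be only part of what the source reports. "The series", "measured", "known", "first", "only" and "open" are said of these compounds alone.

Measured so far in an ADME assay on HCT-116 cells (Homo sapiens) for cytotoxicity, read by CellTiter-Glo, with a stated time of 72 h (a higher number here means a weaker inhibitor, a lower number a stronger inhibitor), each entry a limit of the assay and not a number:

- Compound 1 `Cc1cc(C)c(S(=O)(=O)N2CCC(N3CCC(C)CC3)CC2)c(C)c1`: > 5000 nM
- Compound 2 `Cc1cc(C)c(S(=O)(=O)N2CCC(N3CCC(c4ccccc4)CC3)CC2)c(C)c1`: > 5000 nM
- Compound 3 `Cc1cc(C)c(S(=O)(=O)N2CCC(N3CCC(CCO)CC3)CC2)c(C)c1`: > 5000 nM

Compound 3 gives > 5000 nM, which is a limit, so its position in the series has no number to it. The same holds across the set: the limit of > 5000 nM in this assay, at which 3 of the 3 values shown sit.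

The next step leads to compound 4 `Cc1cc(C)c(S(=O)(=O)N2CCC(c3ccccc3)CC2)c(C)c1`. The change is phenyl in place of 4-(2-hydroxyethyl)piperidin-1-yl on a saturated ring carbon, three ring bonds from the ring nitrogen.

Going by the values given here, three measured steps bear on this only in part: a step that the two limits leave unreadable from compound 1 to compound 2, a step that the two limits leave unreadable from compound 1 to compound 3 and a step that the two limits leave unreadable from compound 2 to compound 3. None of them has a readable size, and each leaves the 4-(2-hydroxyethyl)piperidin-1-yl position occupied by a ring with a substituent, so the whole unit is not removed in any of them. Compound 2 also carries phenyl on a saturated ring carbon, and it gives the limit > 5000 nM.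

Among the compounds with values here, with no sized step to draw on, no change beyond the scatter is expected in this assay, and no direction can be given. The expected step is a step that the limit leaves unreadable from compound 3 to compound 4. Compound 4 is estimated at 8000 nM, with an expected range of 4000 nM to 20000 nM. A report of only a limit is the likeliest outcome.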

Compound 4, half-maximal inhibitory concentration: > 5000 nM
Compound 4: only a limit was reported; the forecaster's own chance of this, stated with the estimate: 85%; the middle value does not contradict the limit.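

In this assay compound 4 gives > 5000 nM, which is a limit. The steps to compound 4 from compound 1 and compound 3 therefore cannot be read. The compounds shown leave open how far each lies from that limit and which change, if any, would give a readable value, as the set offers only one entry: the limit of > 5000 nM in this assay, at which 4 of the 4 values shown sit.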